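The compounds below may be only part of what the source reports. "The series", "measured", "known", "first", "only" and "open" are said of these compounds alone.

Measured so far in a functional assay on MCF7 cells (Homo sapiens) for inhibition, read by sulforhodamine B assay, with a stated time of 48 h; on this read-out higher numbers stand for weaker inhibition of growth and lower numbers for stronger inhibition of growth:
compound 1 `COC(=O)c1sc2cc(-c3ccoc3)cnc2c1N`: > 120000 nM, a limit of the assay.
compound 2 `COC(=O)c1sc2cc(-c3ccc(C(F)(F)F)cc3)cnc2c1N`: > 150000 nM, likewise a limit of the assay.

Compound 1 stands at the limit of > 120000 nM in this assay, at which 1 of the 2 values shown sits; no number exists for it, only that limit. The other value shown, for compound 2, is also a limit, (the limit of > 150000 nM in this assay, at which 1 of the 2 values shown sits). Among the compounds with values here, the two values therefore show nothing about which of the two is the stronger inhibitor of growth, and no step between measured compounds can be stated for the series.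

Compound 3 `COC(=O)c1sc2cc(-c3cccc(N)c3)cnc2c1N` differs from compound 1 by 3-aminophenyl in place of furan-3-yl on an aromatic carbon. Within the data shown here, this change has no measured counterpart among the compounds at hand, and nothing in the data gives ground to expect compound 3 to move into the range where this assay reports a number. The expected step of a number no higher from compound 1 to compound 3 (the limit leaves the size open) is none beyond the scatter, with no direction favoured. Compound 3 is accordingly estimated at 120000 nM, with a range from 30000 nM to 300000 nM, and it is expected that this assay will most likely again return only a limit.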

Compound 3, concentration for 50% growth inhibition: > 150000 nM
Compound 3: only a limit was reported; the forecaster's own chance of this, stated with the estimate: 70%; at least 1.2-fold (0.09 log units) between middle value and limit.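

In this assay compound 3 gives > 150000 nM, a limit of the assay. Within the data shown here, compound 1 also stands only at a limit, and no step between compound 1 and compound 3 can be read. The compounds shown leave open whether any group at this place on the shared core gives a reported number.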